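A few compounds are considered here, and "the series" means these few. Any claim that something is new, unique, unknown or untested is made for them only; others in the source may bear on it.

Three closely related compounds have been tested in a functional assay on HCT-116 cells (Homo sapiens), read by MTT assay, with a stated time of 72 h; a higher number here means a weaker inhibitor, a lower number a stronger inhibitor. Compound 1 `COc1nc(N)nc2c1c(-c1ccccc1)cn2[C@@H]1O[C@H](CO)[C@@H](O)[C@H]1O` carries a phenyl group on the five-membered ring of its core. In this assay compound 1 gives only a limit, > 20000 nM. Compound 2 `COc1nc(N)nc2c1c(-c1cccs1)cn2[C@@H]1O[C@H](CO)[C@@H](O)[C@H]1O` differs from compound 1 by thiophen-2-yl in place of phenyl on an aromatic carbon. In this assay compound 2 likewise gives only a limit, > 20000 nM. Because both results sit at the limit of > 20000 nM in this assay, at which 2 of the 3 values shown sit, the step that the two limits leave unreadable from compound 1 to compound 2 cannot be read.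

Compound 3 `CNc1ncnc2c1c(-c1ccccc1)cn2[C@@H]1O[C@H](CO)[C@@H](O)[C@H]1O` has a different core from compound 1; the difference between the two cores is not broken down here. In this assay compound 3 gives only a limit, > 100000 nM, which sits at the limit of > 100000 nM in this assay, at which 1 of the 3 values shown sits.

Compound 4 `CNc1ncnc2c1c(-c1cccs1)cn2[C@@H]1O[C@H](CO)[C@@H](O)[C@H]1O` is the counterpart of compound 2 on the core of compound 3, differing from compound 3 by thiophen-2-yl in place of phenyl on an aromatic carbon. Around the place of the change, compound 1 shows the ring atom bearing a 3,4-dihydroxy-5-(hydroxymethyl)oxolan-2-yl group, whereas for compound 3 that ring atom is described as bearing a group of 9 heavy atoms, so this is the same kind of change rather than the same change.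

For compound 4 the estimated value in this assay is 150000 nM, with a range from 40000 nM to 600000 nM. This expectation rests on compound 3, which in this assay gives only a limit, > 100000 nM. Within the data shown here, the corresponding expected step is a step that the limit leaves unreadable from compound 3 to compound 4, and since no measured step in this set could be read, that expected step is essentially flat.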

Compound 4, half-maximal inhibitory concentration: > 20000 nM
Compound 4 gave a limit, no number; the forecaster's own chance of this, stated with the estimate: 90%; the middle value is on the limit's open side.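

In this assay, compound 3 and compound 4 each give only a limit and not a number. The step from one to the other therefore cannot be read. The compounds shown leave open how strong any of the four actually is in this assay, and whether thiophen-2-yl in place of phenyl changes that strength on either core.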